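Working notes: adding a methoxy to compound 3

The source may report more compounds than this note shows. Statements on the series, on what has been measured and on what is new or still open speak of the compounds shown alone.

Values so far in a functional assay on CCRF-CEM cells (Homo sapiens) for antiproliferative activity, with a stated time of 72 h; on this read-out higher numbers stand for weaker inhibition and lower numbers for stronger inhibition
- Compound 1 `OC[C@H]1O[C@@H](n2cnc3c(NCc4cccc(Br)c4)ncnc32)[C@H](O)[C@@H]1O`: 5000 nM
- Compound 2 `Cc1cccc(CNc2ncnc3c2ncn3[C@@H]2O[C@H](CO)[C@@H](O)[C@H]2O)c1`: 19100 nM
- Compound 3 `COc1ccccc1CNc1ncnc2c1ncn2[C@@H]1O[C@H](CO)[C@@H](O)[C@H]1O`: 3200 nM

The standing of compound 3 rests on two steps: a 1.6-fold lower number from compound 1 to compound 3 (0.19 log units; within the scatter) stays within the scatter, while a 6.0-fold lower number from compound 2 to compound 3 (0.78 log units; beyond the scatter) goes beyond it. The change to compound 4 `COc1ccc(CNc2ncnc3c2ncn3[C@@H]2O[C@H](CO)[C@@H](O)[C@H]2O)c(OC)c1` is methoxy in place of hydrogen on an aromatic carbon and turns 2-methoxyphenyl into 2,4-dimethoxyphenyl. For the measured compounds named here, no measured step adds a group to an aromatic ring while keeping everything else. The nearest guides are substituent swaps, namely a 3.8-fold higher number from compound 1 to compound 2 (0.58 log units; beyond the scatter) and the two steps above, and those beyond the scatter are modest in size. They show no direction for an added methoxy, so no step beyond the scatter is expected in this assay. The expected change is a 1.3-fold higher number from compound 3 to compound 4 (0.10 log units; within the scatter) and its direction is uncertain. For compound 4 the estimated value is 4000 nM with an expected range from 1300 nM to 13000 nM in this series.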

Compound 4, half-maximal inhibitory concentration: > 166000 nM
Compound 4: no number, only a limit; the forecaster's own chance of this, stated with the estimate: 10%; at least 41-fold (1.61 log units) between middle value and limit.
By their numbers in this assay, from the lowest: compounds 3 and 1 (each within the scatter of the next); then compound 2. At a limit, above all of these: compound 4.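

In this assay compound 4 gives > 166000 nM, which is a limit and not a number. Methoxy in place of hydrogen on an aromatic carbon, para to a large group and meta to a methoxy group, gives an at least 51-fold higher number from compound 3 to compound 4 (1.71 log units; beyond the scatter), so this position is not indifferent to an added group, whereas the earlier swaps were modest at most. The 2,4-dimethoxyphenyl group also stands apart from the 3-methylphenyl and 3-bromophenyl groups, with an at least 8.6-fold higher number from compound 2 to compound 4 (0.93 log units; beyond the scatter) and an at least 33-fold higher number from compound 1 to compound 4 (1.52 log units; beyond the scatter).

Methoxy is the only group shown at this place, so it remains open whether a fluorine, a hydroxyl or an amine there would give the same result. On these data alone, it also remains open whether the result depends on the second methoxy of compound 4, or whether a lone methoxy at this place would give the same.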